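The source may hold more compounds than are shown below. What is called first, only, known or untested is meant among the compounds shown, and "the series" means these compounds.

Two compounds in this series have numbers in an assay on membranes from brain (Cavia porcellus) for binding affinity to Sigma non-opioid intracellular receptor 1 (Homo sapiens), read by radioligand binding; on this read-out higher numbers stand for weaker inhibition and lower numbers for stronger inhibition. Compound 1 `c1ccc2cc(N3CCNCC3)ccc2c1` carries an unsubstituted bicyclic aromatic group on the ring nitrogen and no substituent on the second ring nitrogen; in this assay compound 1 gives 550 nM. Compound 2 `Clc1cccc(N2CCN(CCCc3ccccc3)CC2)c1` carries the 3-chlorophenyl group and the phenylpropyl chain; in this assay compound 2 gives 19.2 nM, the lower of the two numbers, and its gap to compound 1 lies beyond the scatter.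

Compound 3 `Clc1ccc(N2CCN(CCCc3ccccc3)CC2)cc1` is the next compound, and it differs from compound 2 in one place: 4-chlorophenyl in place of 3-chlorophenyl on an amine nitrogen in a ring. Within the data shown here, no measured pair shows this kind of change, so the size of the step cannot be read off from the data. The expected step of a 1.0-fold higher number from compound 2 to compound 3 (0.02 log units; within the scatter) is small, in no particular direction, and not beyond the scatter. Compound 3 is therefore estimated at 20 nM, with a range from 8 nM to 60 nM.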

Compound 3, inhibition constant: 2.9 nM
The estimate for compound 3 lay 6.9-fold (0.84 log units) above the measured number; the measured number lies below the stated range.
By their numbers in this assay, from the lowest: compound 3; then compound 2; then compound 1.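

Among these compounds, with the phenylpropyl chain unchanged, 4-chlorophenyl in place of 3-chlorophenyl on the amine nitrogen in the ring gives a 6.6-fold lower number from compound 2 to compound 3 (0.82 log units; beyond the scatter) in this assay and this is the first step that can be read. The two groups have the same heavy atoms and the same counts, so where the chlorine stands on the phenyl ring is enough on its own to move the number beyond the scatter, which compound 1 could not show since it differs from both in more than one place. Nothing at hand bears on the reason for this step.

Going by these compounds, whether the step holds with a shorter chain or with a phenylbutyl chain on the second ring nitrogen stays open. Also open, on these data alone, is how 4-fluorophenyl, 4-methoxyphenyl or plain phenyl would compare with 4-chlorophenyl in this place.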